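From Methoxypyridine to Cyanophenyl: One Change, One Estimate

The source may report more compounds than this note shows. Statements on the series, on what has been measured and on what is new or still open speak of the compounds shown alone.

Of the compounds shown here, two have been measured in an in vitro functional assay on HEK285-7 cells for antagonist activity at prostaglandin D2 receptor 2 (Homo sapiens), read by BRET and beta-arrestin recruitment; on this read-out higher numbers stand for larger maximal responses and lower numbers for smaller maximal responses. Compound 1 `O=C(O)Cc1sc(Cc2ccccc2-c2ccccc2)nc1-c1ccc(Cl)cc1` gives 50% in this assay. Compound 2 `COc1cc(-c2nc(C(c3ccc(F)cc3)c3ccc(F)cc3)sc2CC(=O)O)ccn1` gives 60% in this assay and so stands highest of the two numbers, but only by a gap that falls within the usual scatter of repeated measurements, so no real order between the two compounds can be claimed. Compound 3 `N#Cc1ccc(-c2nc(C(c3ccc(F)cc3)c3ccc(F)cc3)sc2CC(=O)O)cc1` has not yet been measured. It differs from compound 2 in one place: 4-cyanophenyl in place of 2-methoxypyridin-4-yl on an aromatic carbon. Going by the values given here, no measured pair shows this change, so the data offer no step from which its effect could be read. With the two measured values sitting so close together, the step of a number 5 percentage points lower from compound 2 to compound 3 (within the scatter) is expected to be small and of no clear direction beyond the scatter. Compound 3 is therefore estimated at 55%, within a range from 35% to 75%.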

Compound 3, largest response reached (reported as efficacy), in percent of the reference or control that the assay uses: 30%
Compound 3: middle estimate off by 25 percentage points, on the high side; measured number outside the range, below it.
By their numbers in this assay, from the lowest: compound 3; then compounds 1 and 2 (each within the scatter of the next).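

The position on the aromatic carbon next to the ring nitrogen proves sensitive to what it carries: in this assay, 4-cyanophenyl in place of 2-methoxypyridin-4-yl brings a number 30 percentage points lower from compound 2 to compound 3 (beyond the scatter). Going by these compounds alone, this is the first step read at this position, as compound 1 and compound 2 differ in more than one place. The two groups have the same heavy-atom count and each is a six-membered aromatic ring with no net charge, so the step comes with an exchange that keeps those features, and no measurement at hand accounts for it.

The compounds shown do not separate the ring nitrogen and methoxy group of the leaving group from the nitrile of the entering one. A plain phenyl or a 4-methoxyphenyl group at this position would bear on that question.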